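Swapping the Sulfur Chain of Compound 3 for Amino

A few compounds are considered here, and "the series" means these few. Any claim that something is new, unique, unknown or untested is made for them only; others in the source may bear on it.

Measured compounds:
compound 1, `CSc1nc(N)c2nc(O)n(Cc3ccccc3)c2n1`: 0.1 uM
compound 2, `Nc1nc(SCc2ccccc2)nc2c1nc(O)n2Cc1ccccc1`: 0.1 uM
compound 3, `CCCCCSc1nc(N)c2nc(O)n(Cc3ccccc3)c2n1`: 10 uM

These values come from a functional assay (spleen, spleen) for activation, with Mus musculus as the target; a lower number here means that less compound is needed, a higher number that more compound is needed for the effect. Compound 3 gives the highest number of the three, far from compound 1 and compound 2, whose values lie within the scatter of each other. Compound 4 `Nc1nc(N)c2nc(O)n(Cc3ccccc3)c2n1` differs from compound 3 by amino in place of pentylsulfanyl on an aromatic carbon. Within the data shown here, no measured step removes the sulfur chain altogether; the nearest guides are a 100-fold higher number from compound 1 to compound 3 (2.00 log units; beyond the scatter) and a 100-fold higher number from compound 2 to compound 3 (2.00 log units; beyond the scatter), both large, showing that a longer chain on the sulfur raised the number sharply. Taking the chain away entirely is expected to move the number back down, though the amino group itself is untested here. Compound 4 is therefore expected to show a 33-fold lower number from compound 3 to compound 4 (1.52 log units; beyond the scatter), landing at an estimated 0.3 uM with a range of 0.03 uM to 3 uM.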

Compound 4, minimum effective concentration: 10 uM
For compound 4 the middle estimate is 33-fold (1.52 log units) below the measured one, and the stated range ends below it.
By their numbers in this assay, from the lowest: compounds 1 and 2 (each within the scatter of the next); then compounds 3 and 4 (each within the scatter of the next).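

In this assay, amino in place of the sulfur chain gives no change at the digits printed from compound 3 to compound 4 (within the scatter) but also a 100-fold higher number from compound 2 to compound 4 (2.00 log units; beyond the scatter) and a 100-fold higher number from compound 1 to compound 4 (2.00 log units; beyond the scatter). Losing the chain therefore does not bring the number down: methylsulfanyl and benzylsulfanyl at this position both give far lower numbers than amino, whereas pentylsulfanyl does not. Nothing available explains this difference. Still open, as far as these compounds go, is the chain length at which the number rises, and whether ethylsulfanyl, propylsulfanyl or methoxy here would match compound 1 or compound 4.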